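This account rests on a few compounds, and the source may have more. Where it says the series, first, only, none or still open, it means among the compounds named here.

Values so far in a physicochemical assay for lipophilicity, measured as octanol-water partition; on this read-out higher numbers stand for higher lipophilicity and lower numbers for lower lipophilicity
- compound 1 (`COc1cccc(C(=O)O[C@@H]2C[C@H](C)CC[C@H]2C(C)C)c1`) gives 4.57
- compound 2 (`CC(C)[C@@H]1CC[C@@H](C)C[C@H]1OC(=O)/C=C/c1cccc([N+](=O)[O-])c1`) gives 5.18
- compound 3 (`CC(C)[C@@H]1CC[C@@H](C)C[C@H]1OC(=O)c1ccc(Cl)cc1`) gives 5.34

Compound 3 (5.34) sits well above compound 1 (4.57), while compound 2 (5.18) lies within the usual scatter of compound 3. The next compound is compound 4 (`CC(C)[C@@H]1CC[C@@H](C)C[C@H]1OC(=O)c1ccc(Br)cc1`). For the measured compounds named here, its single change (bromo in place of chloro on an aromatic carbon) is bromo in place of chloro on an aromatic carbon, para to a large group. Going by the values given here, no two measured compounds differ in only one place, so the data hold no direct guide to this swap. A small rise in this assay is expected, not beyond the scatter. The expected size is the estimated step (a number 0.16 log units higher from compound 3 to compound 4 (within the scatter)). For compound 4 the estimated value is 5.5 with an expected range from 5.2 to 5.8 on this scale.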

Compound 4, partition coefficient: 5.61
Estimate against measurement, compound 4: 0.11 log units below, and the stated range covers the measured number.
By their numbers in this assay, from the lowest: compound 1; then compounds 2, 3 and 4 (each within the scatter of the next, the first and the last beyond it).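

For the compounds shown here, this is the first pair that differs in only one place, so the halogen can now be read directly. In this assay, bromo in place of chloro on the aromatic carbon, para to a large group, gives a number 0.27 log units higher from compound 3 to compound 4 (within the scatter), so at this position the two halogens cannot be told apart on this read-out. Nothing at hand gives a reason for this step.

Still open, going by these compounds, is how this position would read with an amine, a carboxylic acid or a longer chain in place of the halogen. On these data alone, whether the same swap reads alike on a different core also remains unknown.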